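The compounds below may be only part of what the source reports. "The series", "measured", "known", "first", "only" and "open" are said of these compounds alone.

Measured in a functional assay on NCI-H520 cells (Homo sapiens) for cytotoxicity; a higher number here means a weaker inhibitor of growth, a lower number a stronger inhibitor of growth:
- compound 1 `CSc1ccc(C2=C(c3ccc(C)c(C)c3)C(=O)N3CCCC3C2)cc1`: 300 nM
- compound 2 `COc1ccc(C2=C(c3ccc(SC)cc3)CC3CCCN3C2=O)cc1`: 800 nM

Of these two, compound 2 has the higher number, so it is the weaker growth inhibitor. The next comparison is compound 3 `CSc1ccc(C2=C(c3ccc(C)cc3)C(=O)N3CCCC3C2)cc1`, which differs from compound 2 as follows: methyl in place of methoxy on an aromatic carbon. This is methyl in place of methoxy on an aromatic carbon, para to a large group, so 4-methoxyphenyl becomes 4-methylphenyl.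

Within the data shown here, only one measured step bears on this change: a 2.7-fold higher number from compound 1 to compound 2 (0.43 log units; beyond the scatter), with 4-methoxyphenyl in place of 3,4-dimethylphenyl on a double-bonded ring carbon. Among the measured compounds shown here, no measured pair isolates methoxy against methyl. Giving up the methoxy is therefore expected to recover part of that step, with a lower number in this assay.

The expected change is a 2.0-fold lower number from compound 2 to compound 3 (0.30 log units; within the scatter). For compound 3 the estimate is 400 nM, with an expected range of 150 nM to 1000 nM.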

Compound 3, concentration for 50% growth inhibition: 900 nM
Compound 3: middle estimate off by 2.3-fold (0.35 log units), on the low side; low and high end bracket the measured number.
By their numbers in this assay, from the lowest: compound 1; then compounds 2 and 3 (each within the scatter of the next).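

In this assay, the swap at this place, para to a large group, separates nothing: a 1.1-fold higher number from compound 2 to compound 3 (0.05 log units; within the scatter), so methoxy and methyl cannot be told apart here. The step with hydrogen in place of methyl, a 3.0-fold higher number from compound 1 to compound 3 (0.48 log units; beyond the scatter), is about as large as the earlier step from compound 1 to compound 2, so within these three compounds the difference tracks with the 3,4-dimethylphenyl of compound 1 and not with methoxy as such. Nothing on hand accounts for either step.

Going by these compounds, it remains open whether a different group at this place, such as an amine, a carboxylic acid or a longer chain like butyl, would depart from compound 2 and compound 3. Also open, on these data alone, is whether other substituents alongside the 4-methyl group would match the lower number of compound 1.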